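A Methoxy-Bearing Substituent on the Ring Nitrogen

The compounds below may be only part of what the source reports. "The series", "measured", "known", "first", "only" and "open" are said of these compounds alone.

Compound 1 `CCCC(C)n1c(CC)nc2c(-c3ccc(C(F)(F)F)cc3Cl)ccnc21` — 1.1 nM
Compound 2 `CCc1nc2c(-c3ccc(Cl)cc3Cl)ccnc2n1[C@H](C)C1CC1` — 0.6 nM
Compound 3 `CCCC(C)n1c(CC)nc2c(-c3ccc(Cl)cc3Cl)ccnc21` — 0.5 nM

In an assay for binding affinity to Corticotropin releasing factor receptor (Rattus norvegicus) (on this read-out lower numbers stand for stronger inhibition and higher numbers for weaker inhibition), compound 3 has the lowest number of the three. The step of a 2.2-fold lower number from compound 1 to compound 3 (0.34 log units; beyond the scatter) lies beyond the scatter, whereas the step of a 1.2-fold lower number from compound 2 to compound 3 (0.08 log units; within the scatter) lies within it, so compound 2 and compound 3 cannot be ordered.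

Compound 4 `CCc1nc2c(-c3ccc(Cl)cc3Cl)ccnc2n1C(CCOC)C1CC1` differs from compound 3 by 1-cyclopropyl-3-methoxypropyl in place of 1-methylbutyl on an aromatic nitrogen. Within the data shown here, only the step of a 1.2-fold lower number from compound 2 to compound 3 (0.08 log units; within the scatter) bears on this change, as it also exchanges the group on that nitrogen, and it stayed within the scatter. Among the measured compounds shown here, no measured compound carries a methoxy group there, so that part of the change is untested. Compound 4 is therefore expected to land close to compound 3, with a 2.0-fold higher number from compound 3 to compound 4 (0.30 log units; within the scatter) as the expected step. The estimate for compound 4 is 1 nM, ranging from 0.3 nM to 3.5 nM.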

Compound 4, inhibition constant: 1.5 nM
Compound 4: the middle estimate sits 1.5-fold (0.18 log units) below what was measured; the measured number falls inside the stated range.
By their numbers in this assay, from the lowest: compounds 3, 2, 1 and 4 (each within the scatter of the next, the first and the last beyond it).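

In this assay, the earlier exchange on this nitrogen stayed within the scatter, but 1-cyclopropyl-3-methoxypropyl gives a step beyond it against both neighbours: a 3.0-fold higher number from compound 3 to compound 4 (0.48 log units; beyond the scatter) and a 2.5-fold higher number from compound 2 to compound 4 (0.40 log units; beyond the scatter). The position therefore does not accept every group without loss, although both steps are modest. Nothing available explains this loss.

Whether the oxygen or the longer chain accounts for the steps remains open. A compound with an all-carbon chain, or with a hydroxyl or an amine in place of the methoxy group, would separate the two.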